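This account rests on a few compounds, and the source may have more. Where it says the series, first, only, none or still open, it means among the compounds named here.

In a physicochemical assay for solubility, at pH 7.4 (a lower number here means a less soluble compound, a higher number a more soluble compound), three compounds sharing one core have been measured. Compound 1 `CC(=O)N1CCc2c(C)c3c(n2-c2ccc(C(N)=O)c(c2)N[C@@H](C)[C@H](C)C1)CC(C)(C)CC3=O` gives 38 ug/mL and compound 2 `Cc1c2c(n3c1CCN(C(=O)CN)C[C@@H](C)[C@H](C)Nc1cc-3ccc1C(N)=O)CC(C)(C)CC2=O` gives 46 ug/mL, and a 1.2-fold higher number from compound 1 to compound 2 (0.08 log units; within the scatter) shows that these two cannot be told apart. Compound 3 `Cc1c2c(n3c1CCN(C(=O)[C@@H](N)C(C)C)C[C@@H](C)[C@H](C)Nc1cc-3ccc1C(N)=O)CC(C)(C)CC2=O` gives > 100 ug/mL, which is a limit of the assay and not a number. This is the limit of > 100 ug/mL in this assay, at which 1 of the 3 values shown sits. The measured steps that reach it are an at least 2.6-fold higher number from compound 1 to compound 3 (0.42 log units; beyond the scatter) and an at least 2.1-fold higher number from compound 2 to compound 3 (0.33 log units; beyond the scatter), both beyond the scatter.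

Compound 4 `Cc1c2c(n3c1CCN(C(=O)C(C)(C)N)C[C@@H](C)[C@H](C)Nc1cc-3ccc1C(N)=O)CC(C)(C)CC2=O` follows from compound 3 by one change, 1-amino-1-methylethyl in place of 1-amino-2-methylpropyl on a carbonyl carbon. For the measured compounds named here, no measured step makes this exact swap. The closest is an at least 2.1-fold higher number from compound 2 to compound 3 (0.33 log units; beyond the scatter), where isopropyl replaces hydrogen on the same chain carbon. Compound 4 keeps the amino group and stays branched, so it is expected to land closer to compound 3 than to compound 2, with any fall small and perhaps within the scatter. The expected change is an at least 1.1-fold lower number from compound 3 to compound 4 (0.07 log units; that floor lies within the scatter). For compound 4 the estimate is 85 ug/mL, with an expected range of 40 ug/mL to 180 ug/mL.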

Compound 4, solubility: > 100 ug/mL
Compound 4: a limit, no number (the forecaster's own chance of this, stated with the estimate: 45%); middle value at least 1.1-fold (0.07 log units) away from the limit.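

In this assay the rise seen with 1-amino-2-methylpropyl on this carbonyl carbon does not depend on that exact group or on its defined stereocentre. With 1-amino-1-methylethyl, which has no defined stereocentre, the rise still appears against both smaller groups, methyl (an at least 2.6-fold higher number from compound 1 to compound 4 (0.42 log units; beyond the scatter)) and aminomethyl (an at least 2.1-fold higher number from compound 2 to compound 4 (0.33 log units; beyond the scatter)). Compound 3 and compound 4 cannot be ordered, and the step between them cannot be read, because each value is a limit and not a number: the limit of > 100 ug/mL in this assay, at which 2 of the 4 values shown sit.

The compounds shown leave open how the two branched amino groups compare once real numbers are available. They also leave open whether the rise survives with a carboxylic acid or a hydroxyl in place of the amino group on this chain.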